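A Methyl Group Moves: The Expected Half-Life of Compound 3

The source may report more compounds than this note shows. Statements on the series, on what has been measured and on what is new or still open speak of the compounds shown alone.

In an ADME assay, at pH 3 (a lower number here means that the compound disappears faster, a higher number that the compound lasts longer), compound 1 (`COc1cnc(C[S+]([O-])c2nc3cc(OC(F)(F)C(F)F)ccc3[nH]2)cc1OC`) gives 0.317 h as its half-life, while compound 2 (`COc1ccnc(C[S+]([O-])c2nc3cc(OC(F)(F)C(F)F)ccc3[nH]2)c1C`) gives 0.0833 h and so stands lowest of the two, with a gap to compound 1 that lies beyond the usual scatter. Compound 3 (`COc1cc(C[S+]([O-])c2nc3cc(OC(F)(F)C(F)F)ccc3[nH]2)ncc1C`) has not yet been measured. It has the same atoms as compound 2, joined differently (4-methoxy-5-methylpyridin-2-yl in place of 4-methoxy-3-methylpyridin-2-yl on a saturated chain carbon bound to a sulfur): 4-methoxy-5-methylpyridin-2-yl in place of 4-methoxy-3-methylpyridin-2-yl on a saturated chain carbon bound to a sulfur.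

Among the compounds with values here, no measured pair differs in one place alone, so the size of this step can only be judged loosely. Compound 1 at 0.317 h shows that a longer half-life occurs among these compounds, so a modest rise is expected rather than a fall. The expected change is a 2.4-fold higher number from compound 2 to compound 3 (0.38 log units; beyond the scatter) towards a longer half-life, although the range also allows for no real change. For compound 3 the estimated half-life is 0.2 h with a range from 0.09 h to 0.45 h expected for repeat measurements.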

Compound 3, half-life: 0.1 h
Compound 3: the middle estimate sits 2.0-fold (0.30 log units) above what was measured; the measured number falls inside the stated range.
By their numbers in this assay, from the lowest: compounds 2 and 3 (each within the scatter of the next); then compound 1.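

Moving the methyl group, with 4-methoxy-5-methylpyridin-2-yl in place of 4-methoxy-3-methylpyridin-2-yl on a saturated chain carbon bound to a sulfur, gives in this assay a 1.2-fold higher number from compound 2 to compound 3 (0.08 log units; within the scatter), so the half-life does not distinguish these two groups at this place. Within the data shown here, the other one-place comparison, methyl in place of methoxy on an aromatic carbon, gives a 3.2-fold lower number from compound 1 to compound 3 (0.50 log units; beyond the scatter), which shows for the first time a single change that separates compounds and ties the gap between compound 1 and compound 3 to that methoxy group rather than to where the methyl group sits. Nothing measured on these compounds explains either step.

Among the compounds shown, that aromatic carbon carries only methyl or methoxy, so what an ethoxy group, a fluorine atom or an amine would do to the half-life there remains open. Also open, from the compounds shown here alone, is whether the same exchange of methyl and methoxy would give a step of similar size within the 4-methoxy-3-methylpyridin-2-yl group of compound 2.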